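The compounds below may be only part of what the source reports. "The series", "measured", "known", "first", "only" and "open" are said of these compounds alone.

Working notes. Compound 3 `CC(C)(C)[Si](C)(C)O[C@H]1CCCO[C@@H]1/C=C/CO` gives 61000 nM in a functional assay on MCF7S cells (Homo sapiens) (on this read-out lower numbers stand for stronger inhibition of growth and higher numbers for weaker inhibition of growth), the highest of the three numbers recorded so far; compound 1 `CC(C)(C)[Si](C)(C)O[C@H]1CCCO[C@@H]1CCO` gives 55000 nM in this assay, a gap within the scatter, while compound 2 `COC(=O)/C=C/C[C@H]1OCCC[C@@H]1O[Si](C)(C)C(C)(C)C` gives 18000 nM. Compound 4 `COC(=O)/C=C\[C@H]1OCCC[C@@H]1O[Si](C)(C)C(C)(C)C` differs from compound 3 by 2-(methoxycarbonyl)ethenyl in place of 3-hydroxyprop-1-en-1-yl on a saturated ring carbon. For the measured compounds named here, two measured steps bear on the exchange of a hydroxyl-bearing chain for a methoxycarbonyl-bearing one: a 3.1-fold lower number from compound 1 to compound 2 (0.49 log units; beyond the scatter), and in the reverse sense a 3.4-fold higher number from compound 2 to compound 3 (0.53 log units; beyond the scatter). Both point the same way, so a modest step toward a lower number is expected in this assay. Compound 4 is therefore estimated at 20000 nM, with a range of 8000 nM to 50000 nM, meaning an expected step of a 3.1-fold lower number from compound 3 to compound 4 (0.48 log units; beyond the scatter).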

Compound 4, concentration for 50% growth inhibition: 32000 nM
Compound 4: the middle estimate sits 1.6-fold (0.20 log units) below what was measured; low and high end bracket the measured number.
By their numbers in this assay, from the lowest: compounds 2, 4, 1 and 3 (each within the scatter of the next, the first and the last beyond it).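

In this assay the step of a 1.9-fold lower number from compound 3 to compound 4 (0.28 log units; within the scatter) and the step of a 1.7-fold lower number from compound 1 to compound 4 (0.24 log units; within the scatter) and the step of a 1.8-fold higher number from compound 2 to compound 4 (0.25 log units; within the scatter) all stay within the scatter, so 2-(methoxycarbonyl)ethenyl on this saturated ring carbon does not separate from any of the three earlier groups. Unlike compound 2, which stands beyond the scatter from compound 1 and compound 3, compound 4 carries the methoxycarbonyl group without such a separation from the hydroxyl-bearing chains. Nothing at hand gives a reason for this.

Still open, from the compounds shown here alone, is whether a carboxylic acid or an amide in place of the methyl ester would move the number beyond the scatter at this position.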